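Carboxy to hydroxymethyl on the amide side chain

The source may report more compounds than this note shows. Statements on the series, on what has been measured and on what is new or still open speak of the compounds shown alone.

In an ADME assay on L02 cells (Homo sapiens) for antiproliferative activity, read by MTT assay, with a stated time of 48 h (a higher number here means a weaker inhibitor, a lower number a stronger inhibitor), compound 1 `CCn1c(C(=O)NCCCN(C)C)ccc1C(CC)(CC)c1ccc(OCCC(O)(CC)CC)c(C)c1` gives 2420 nM and compound 3 `CCn1c(C(=O)NC(C)C(=O)O)ccc1C(CC)(CC)c1ccc(OCCC(O)(CC)CC)c(C)c1` gives 4040 nM. These two values lie within the scatter of each other, as a 1.7-fold higher number from compound 1 to compound 3 (0.22 log units; within the scatter) shows. Compound 2 `CCOc1ccc(NC(=O)c2ccc(C(CC)(CC)c3ccc(OCCC(O)(CC)CC)c(C)c3)n2CC)cc1` gives > 50000 nM, which is a limit of the assay. Its 4-ethoxyphenyl group accounts for the two large steps, an at least 20-fold higher number from compound 1 to compound 2 (1.31 log units; beyond the scatter) and an at least 12-fold lower number from compound 2 to compound 3 (1.09 log units; beyond the scatter).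

Compound 4 `CCn1c(C(=O)NC(C)CO)ccc1C(CC)(CC)c1ccc(OCCC(O)(CC)CC)c(C)c1` carries one change: hydroxymethyl in place of carboxy on a saturated chain carbon bound to an amide-type nitrogen and a saturated chain carbon, hydroxymethyl in place of carboxy. No aryl group enters, so the closer precedent is a 1.7-fold higher number from compound 1 to compound 3 (0.22 log units; within the scatter), and no step beyond the scatter is expected in this assay. The expected change is a 1.2-fold higher number from compound 3 to compound 4 (0.09 log units; within the scatter). Compound 4 is estimated at 5000 nM, with an expected range of 1800 nM to 20000 nM.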

Compound 4, half-maximal inhibitory concentration: 4840 nM
The estimate for compound 4 lay 1.0-fold (0.01 log units) above the measured number; the range from low to high includes it.
By their numbers in this assay, from the lowest: compounds 1, 3 and 4 (each within the scatter of the next). At a limit, above all of these: compound 2.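

In this assay, hydroxymethyl in place of carboxy on a saturated chain carbon bound to an amide-type nitrogen and a saturated chain carbon gives a 1.2-fold higher number from compound 3 to compound 4 (0.08 log units; within the scatter). With 1-(hydroxymethyl)ethyl in place of 3-(dimethylamino)propyl giving a 2.0-fold higher number from compound 1 to compound 4 (0.30 log units; within the scatter), compounds 1, 3 and 4 form one group, and only the 4-ethoxyphenyl amide stands apart: an at least 10-fold lower number from compound 2 to compound 4 (1.01 log units; beyond the scatter). That step starts from a limit in compound 2, not from a number: the limit of > 50000 nM in this assay, at which 1 of the 4 values shown sits.

Open, as far as these compounds go, is whether an amine or a methyl ether in place of hydroxymethyl at this carbon also stays within the scatter. Also open, from the compounds shown here alone, is whether a longer chain there does the same.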